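Adding Chloro to Two Related Cores: What to Expect

The source may report more compounds than this note shows. Statements on the series, on what has been measured and on what is new or still open speak of the compounds shown alone.

The measured compounds:

Compound 1 `Clc1ccc(Nc2ccc(N3CC4CC(C3)N4)cn2)cc1` gives 2.49 nM in an assay on cell membranes for displacement of a labelled ligand from Neuronal acetylcholine receptor; alpha4/beta2 (Rattus norvegicus); a higher number here means a weaker inhibitor, a lower number a stronger inhibitor.
Compound 2 `c1ccc(Nc2ccc(N3CC4CC(C3)N4)nn2)cc1` gives 441 nM in this assay.
Compound 3 `c1ccc(Nc2ccc(N3CC4CC(C3)N4)cn2)cc1` gives 2.66 nM in this assay.

Compounds 1 and 3 share one core and differ only in one place: chloro in place of hydrogen on an aromatic carbon. This change made a 1.1-fold lower number from compound 3 to compound 1 (0.03 log units; within the scatter), so the chloro substituent left the result essentially unchanged. Compound 2 carries a different core, and the difference between the two cores is not broken down here; what the numbers show is that compound 2 gives the highest value of the three, far beyond the scatter from both compound 1 and compound 3.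

Compound 4 `Clc1cccc(Nc2ccc(N3CC4CC(C3)N4)nn2)c1` is the unmeasured partner of compound 2. It differs from compound 2 by chloro in place of hydrogen on an aromatic carbon. For the measured compounds named here, this is the same kind of change as the one from compound 3 to compound 1, though not the same: in compound 1 the chloro sits para to a large group, in compound 4 it sits meta to a large group, and the two pairs rest on different cores.

Since the earlier step, a 1.1-fold lower number from compound 3 to compound 1 (0.03 log units; within the scatter), was within the scatter, the expectation is that the step from compound 2 to compound 4 will also be small, estimated as a 1.3-fold lower number from compound 2 to compound 4 (0.10 log units; within the scatter). Compound 4 is therefore expected to give about 350 nM in this assay, estimated to lie between 120 nM and 1000 nM.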

Compound 4, inhibition constant: 1540 nM
Beside the measured number, compound 4's estimate is 4.4-fold (0.64 log units) below it; measured number above the stated range.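

Adding the chloro did not act alike on the two cores. In this assay the change gives a 3.5-fold higher number from compound 2 to compound 4 (0.54 log units; beyond the scatter), a modest weakening, while on the other core it gives a 1.1-fold lower number from compound 3 to compound 1 (0.03 log units; within the scatter), so the near absence of an effect on one core did not carry over to the other, and the two results differ by more than repeated measurement would explain: the same change on two cores in this assay, a 1.1-fold lower number (0.03 log units; within the scatter) from compound 3 to compound 1 and a 3.5-fold higher number (0.54 log units; beyond the scatter) from compound 2 to compound 4, 3.7-fold (0.57 log units) apart, beyond the scatter of two such steps

What this does not show is the reason for the difference, or any rule for the series as a whole: the two pairs differ in their core and also in where the chloro sits, with compound 4 carrying it meta to a large group and compound 1 carrying it elsewhere on the ring, and two pairs cannot separate these influences.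

The compounds shown leave open whether the two cores would still respond differently with the chloro at the same place on the ring in both. They also leave open whether another group at these places, such as fluoro, methoxy or an amine, would leave the number unchanged, as in compound 1, or raise it, as in compound 4.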